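Swapping the ring substituent for a piperidinyl amide

The source may report more compounds than this note shows. Statements on the series, on what has been measured and on what is new or still open speak of the compounds shown alone.

Measured so far in a physicochemical assay for solubility; a lower number here means a less soluble compound, a higher number a more soluble compound:
compound 1, `O=C(c1ccccc1)N1CCC(NS(=O)(=O)c2cc(S(=O)(=O)c3ccccc3)ccc2C(F)(F)F)CC1`, gives 12500 nM.
compound 2, `CN(C)c1ccc(C(=O)N2CCC(NS(=O)(=O)c3cc(S(=O)(=O)c4ccccc4)ccc3C(F)(F)F)CC2)cc1`, gives 50000 nM.
compound 3, `N#Cc1cccc(S(=O)(=O)N2CCC(NS(=O)(=O)c3cc(S(=O)(=O)c4ccccc4)ccc3C(F)(F)F)CC2)c1`, gives 6300 nM.

Compound 3 has the lowest of the three numbers in this assay. Its nearest neighbour is compound 1, and that gap, a 2.0-fold lower number from compound 1 to compound 3 (0.30 log units; within the scatter), is within the scatter, so the two cannot be ordered. Compound 2 stands furthest away: a 7.9-fold lower number from compound 2 to compound 3 (0.90 log units; beyond the scatter). The step of a 4.0-fold higher number from compound 1 to compound 2 (0.60 log units; beyond the scatter) shows that a change at the outer end of the shared core can move the number beyond the scatter.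

Compound 4, `O=C(C1CCNCC1)N1CCC(NS(=O)(=O)c2cc(S(=O)(=O)c3ccccc3)ccc2C(F)(F)F)CC1`, is not yet measured. It differs from compound 3 as follows: (piperidin-4-yl)carbonyl in place of (3-cyanophenyl)sulfonyl on an amine nitrogen in a ring.

Within the data shown here, two measured steps touch the same amine nitrogen in a ring: a 2.0-fold lower number from compound 1 to compound 3 (0.30 log units; within the scatter), within the scatter, and a 7.9-fold lower number from compound 2 to compound 3 (0.90 log units; beyond the scatter), beyond it. Among the measured compounds shown here, the group that enters in compound 4 brings a hydrogen-bond donor that none of the three measured groups at this position had, so the new step has no direct precedent. Given that compound 2 reached 50000 nM with a nitrogen-bearing group at this position, compound 4 is expected to move upward, by a 16-fold higher number from compound 3 to compound 4 (1.20 log units; beyond the scatter), to an estimated 100000 nM with a range from 25000 nM to 400000 nM.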

Compound 4, solubility: 100000 nM
The estimate for compound 4 equals the measured number at the digits printed; the measured number falls inside the stated range.
By their numbers in this assay, from the lowest: compounds 3 and 1 (each within the scatter of the next); then compounds 2 and 4 (each within the scatter of the next).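

In this assay, the step of a 16-fold higher number from compound 3 to compound 4 (1.20 log units; beyond the scatter) is the largest listed at this amine nitrogen in a ring, so this position can shift the number further than the earlier compounds showed. The step of an 8.0-fold higher number from compound 1 to compound 4 (0.90 log units; beyond the scatter) keeps the carbonyl in place and changes only phenyl to piperidin-4-yl, which shows that the group on that carbonyl carbon alone can carry a change beyond the scatter. The step of a 2.0-fold higher number from compound 2 to compound 4 (0.30 log units; within the scatter) lies within the scatter, so compound 2 and compound 4 cannot be ordered, although one has an aromatic ring and the other a non-aromatic ring; both stand beyond the scatter from compound 1 and compound 3, but the nitrile nitrogen of compound 3 shows that having a nitrogen in the group is not enough to place a compound with them.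

Nothing available explains why the number moves at this position. A cyclohexyl group on the same carbonyl carbon, with carbon in place of the ring nitrogen, would show whether that nitrogen is needed, and a methyl on the ring nitrogen would show whether its hydrogen is.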